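Hydroxy on the phenyl of compound 2

The compounds below may be only part of what the source reports. "The series", "measured", "known", "first", "only" and "open" are said of these compounds alone.

In a functional assay on A 172 cells (Homo sapiens) for cytotoxicity, read by colorimetric assay and MTT assay (on this read-out lower numbers stand for stronger inhibition and higher numbers for weaker inhibition), compound 1 (`COc1ccc2cc(-c3ccccc3)c(O)nc2c1`) gives (10000 nM). Compound 2 (`COc1cc(OC)c2cc(-c3ccccc3)c(O)nc2c1`) gives (10000 nM). Compound 3 (`COc1ccc(-c2cc3cccc(OC)c3nc2O)cc1`) gives (10000 nM). Compound 2 therefore stands level with both others. Compound 4 (`COc1cc(OC)c2cc(-c3ccc(O)cc3)c(O)nc2c1`) follows from compound 2 by one change (hydroxy in place of hydrogen on an aromatic carbon), hydroxy in place of hydrogen on an aromatic carbon, read further out as phenyl to 4-hydroxyphenyl. Within the data shown here, only one measured step bears on it (no change at the digits printed from compound 1 to compound 2 (within the scatter)), a methoxy in place of hydrogen on an aromatic carbon, and that step stays within the scatter. Among the measured compounds shown here, no measured compound carries the 4-hydroxyphenyl group. The expected step (no change at the digits printed from compound 2 to compound 4 (within the scatter)) is therefore none beyond the scatter in this assay as a working assumption. For compound 4 the estimated value is (10000 nM), with an expected range from (4000 nM) to (20000 nM).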

Compound 4, half-maximal inhibitory concentration: 10000 nM
Compound 4: middle estimate and measured number agree at the digits printed; the range from low to high includes it.
By their numbers in this assay, from the lowest: compounds 1, 2, 3 and 4 (each within the scatter of the next).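

The change from phenyl to 4-hydroxyphenyl gives no change at the digits printed from compound 2 to compound 4 (within the scatter) in this assay on the cytotoxicity read-out. Among these compounds, it is the first single-change step on the phenyl itself, and a hydroxy at this place, para to a large group, leaves the printed value unchanged. Nothing measured here offers a reason for this flat result.

Still open, on these data alone, is whether an amine or a carboxylic acid at the same place would separate from compound 4 at 10000 nM in this assay. Also open, as far as these compounds go, is whether a longer chain on the phenyl would do so.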